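The source may hold more compounds than are shown below. What is called first, only, known or untested is meant among the compounds shown, and "the series" means these compounds.

Measured compounds:
Compound 1, `COc1cc(NC(=O)Nc2cc(Nc3ccc(F)c(Cl)c3)ncn2)cc(OC)c1`: 77.5%
Compound 2, `CCc1cccc(Nc2cc(NC(=O)Nc3cc(OC)cc(OC)c3)ncn2)c1`: 82.1%
Compound 3, `COc1cc(NC(=O)Nc2cc(Nc3cc(I)ccc3OC)ncn2)cc(OC)c1`: 91%

In a functional assay on PC-9 cells (Homo sapiens) for inhibition, read by MTT assay, with a stated time of 48 h, tested at 10 uM (a higher number here means more inhibition at the concentration tested (going by the name of the read-out), a lower number less inhibition), compound 3 gives the highest of the three numbers; its nearest neighbour is compound 2, a gap within the scatter, and only the gap to compound 1 lies beyond it. Compound 4, `COc1cc(NC(=O)Nc2cc(Nc3ccc(Br)cc3OC)ncn2)cc(OC)c1`, differs from compound 3 in one place: 4-bromo-2-methoxyphenyl in place of 5-iodo-2-methoxyphenyl on a nitrogen on an aromatic ring. For the measured compounds named here, the steps that bear on this change are a number 13.5 percentage points higher from compound 1 to compound 3 (beyond the scatter) and a number 8.9 percentage points higher from compound 2 to compound 3 (within the scatter), both swaps of the aryl group on the same nitrogen, one modest and one within the scatter. Since compound 4 keeps a methoxyphenyl with a halogen, only a small shift is expected, a number 6 percentage points lower from compound 3 to compound 4 (within the scatter). Compound 4 is therefore estimated at 85%, between 70% and 95%.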

Compound 4, a percentage reported as inhibition, at one concentration (the size of the read-out at that concentration, not a potency): 83%
Estimate against measurement, compound 4: 2 percentage points above, within the range that was stated.
By their numbers in this assay, from the lowest: compounds 1, 2, 4 and 3 (each within the scatter of the next, the first and the last beyond it).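

Swapping 5-iodo-2-methoxyphenyl for 4-bromo-2-methoxyphenyl on this nitrogen in this assay gives a number 8 percentage points lower from compound 3 to compound 4 (within the scatter), so changing both the halogen and its place on the ring stays within the scatter here. For the compounds shown here, compound 4 also sits close to the two other aryl groups, with a number 0.9 percentage points higher from compound 2 to compound 4 (within the scatter) and a number 5.5 percentage points higher from compound 1 to compound 4 (within the scatter), so the one gap beyond the scatter, between compound 1 and compound 3, has no counterpart with the bromo group. Nothing shown accounts for these numbers. The compounds shown leave open whether the halogen itself matters, since each aryl group here carries a halogen or an ethyl group and none carries an amine or a carboxylic acid.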